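Cytotoxicity in HEL cells: amino to trifluoromethoxy

The compounds below may be only part of what the source reports. "The series", "measured", "known", "first", "only" and "open" are said of these compounds alone.

Compound 1 `CCCc1ccc(C#CC#Cc2cn([C@H]3C[C@H](O)[C@@H](CO)O3)c(=O)[nH]c2=O)cc1`: 52000 nM
Compound 2 `Nc1ccc(C#CC#Cc2cn([C@H]3C[C@H](O)[C@@H](CO)O3)c(=O)[nH]c2=O)cc1`: > 100000 nM

In an ADME assay on HEL cells (Homo sapiens), read by cell counting, with a stated time of 3 days (a lower number here means that less compound is tolerated, a higher number that more compound is tolerated), compound 1 gives 52000 nM. For compound 2 this assay reports only a limit, > 100000 nM, so compound 2 stands at the top of the measured range without a number. Going by the values given here, the single measured step, an at least 1.9-fold higher number from compound 1 to compound 2 (0.28 log units; that floor lies within the scatter), is bounded by the limit of > 100000 nM in this assay, at which 1 of the 2 values shown sits, and is therefore only a floor.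

Compound 3 `O=c1[nH]c(=O)n([C@H]2C[C@H](O)[C@@H](CO)O2)cc1C#CC#Cc1ccc(OC(F)(F)F)cc1` carries trifluoromethoxy in place of amino on an aromatic carbon. Among the compounds with values here, no measured step involves trifluoromethoxy, so the only guidance is that the propyl analogue compound 1 sits at 52000 nM. The amino analogue compound 2, in turn, is reported only as a limit. Compound 3 is expected to fall between those two positions, with the step of an at least 1.4-fold lower number from compound 2 to compound 3 (0.15 log units; that floor lies within the scatter) expected from compound 2. The estimate for compound 3 in this assay is 70000 nM, with a range from 30000 nM to 150000 nM, and a fair chance that only a limit is returned.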

Compound 3, half-maximal cytotoxic concentration: 55000 nM
The estimate for compound 3 lay 1.3-fold (0.10 log units) above the measured number; the measured number falls inside the stated range.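

Trifluoromethoxy and propyl at this position cannot be told apart in this assay, with a 1.1-fold higher number from compound 1 to compound 3 (0.02 log units; within the scatter) as the step between them. As far as these compounds go, replacing amino with trifluoromethoxy gives an at least 1.8-fold lower number from compound 2 to compound 3 (0.25 log units; that floor lies within the scatter), so the series still shows no established change at this position, and the true size of this step remains unknown: the limit of > 100000 nM in this assay, at which 1 of the 3 values shown sits. Compound 2 is reported only as a limit, > 100000 nM.

The compounds shown leave open whether any group at this position can move the number beyond the usual scatter, since the only step from amino is a floor. A carboxylic acid or a chain longer than propyl on the same aromatic carbon would test whether tolerance in this assay depends on the group there at all.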